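From 3,4-dimethoxyphenyl to phenyl: compound 3 to compound 4

A few compounds are considered here, and "the series" means these few. Any claim that something is new, unique, unknown or untested is made for them only; others in the source may bear on it.

Values so far in a functional assay, read by spectrophotometry, with a stated time of 5 min; a lower number here means a stronger inhibitor, a higher number a weaker inhibitor

- compound 1 `COc1cc(/C=C/C(=O)C(=Cc2ccc(O)cc2)C(=O)/C=C/c2ccc(O)c(OC)c2)ccc1O` gives 48700000 nM
- compound 2 `COc1cc(/C=C/C(=O)C(=Cc2ccccc2)C(=O)/C=C/c2ccc(O)c(OC)c2)ccc1O` gives 84400000 nM
- compound 3 `CCOc1cc(/C=C/C(=O)C(=Cc2ccc(OC)c(OC)c2)C(=O)/C=C/c2ccc(O)c(OCC)c2)ccc1O` gives 53200000 nM

Compound 3 stands within the usual scatter of both compound 1 and compound 2, so these three numbers cannot be put in a reliable order. All of them are very large for this kind of read-out, which means weak inhibition.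

Compound 4 `CCOc1cc(/C=C/C(=O)C(=Cc2ccccc2)C(=O)/C=C/c2ccc(O)c(OCC)c2)ccc1O` has not been measured yet. Its difference from compound 3 is this (phenyl in place of 3,4-dimethoxyphenyl on a double-bonded chain carbon bound to a double-bonded chain carbon). In plain terms, phenyl takes the place of 3,4-dimethoxyphenyl on a double-bonded chain carbon bound to a double-bonded chain carbon, while the rest of the structure stays the same.

Among the measured compounds shown here, only one measured step bears on this change, and it is not the same swap. It concerns hydrogen in place of hydroxy on an aromatic carbon (and amounts to a 1.7-fold higher number from compound 1 to compound 2 (0.24 log units; within the scatter)), which stays within the scatter. Compound 2 (at 84400000 nM) also carries phenyl at this place, on a core with methoxy where compound 4 has ethoxy, and its value also lies within the scatter of compound 3.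

No step beyond the scatter is therefore expected, and the estimated step is small (a 1.3-fold higher number from compound 3 to compound 4 (0.12 log units; within the scatter)). Compound 4 is expected at 70000000 nM (estimated range 38000000 nM to 125000000 nM).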

Compound 4, half-maximal inhibitory concentration: 91400000 nM
Compound 4: middle estimate off by 1.3-fold (0.12 log units), on the low side, within the range that was stated.
By their numbers in this assay, from the lowest: compounds 1, 3, 2 and 4 (each within the scatter of the next).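

In this assay, putting phenyl in place of 3,4-dimethoxyphenyl on a double-bonded chain carbon bound to a double-bonded chain carbon gives a 1.7-fold higher number from compound 3 to compound 4 (0.24 log units; within the scatter), so this direct comparison shows no reliable effect from removing both methoxy groups from this ring. The earlier step at this place, a 1.7-fold higher number from compound 1 to compound 2 (0.24 log units; within the scatter), involved a different swap on a different core and also stayed within the scatter, so neither of the two measured changes at this place can be told apart from repeat-measurement noise. The data offer no measured explanation for this small response.

All the compounds shown sit at very large values in this assay, which leaves open whether any group at this place can produce a step beyond the scatter. An aminomethyl or carboxylic acid group on the phenyl ring, or a longer chain such as butoxy on it, would test whether this place can matter at all.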